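Secondary amine series: aryl swap on the shared core

This account rests on a few compounds, and the source may have more. Where it says the series, first, only, none or still open, it means among the compounds named here.

Compound 3 `c1ccc(CCc2ccc3c(NCCCNCc4ccco4)ccnc3c2)cc1` gives 9.47 in a physicochemical assay for acid dissociation. Compound 1 `COc1ccc(-c2ccc3c(NCCCNCc4cccc(OC)c4O)ccnc3c2)cc1` gives 9.47 in this assay, and compound 2 `COc1ccc(F)cc1CNCCCNc1ccnc2cc(C3CCCCC3)ccc12` gives 9.47 in this assay; compound 3 is level with both at the digits shown, the two gaps lying within the scatter. Among the compounds with values here, no single-point step between measured compounds is available, so nothing here has yet moved the read-out. Compound 4 `COc1ccccc1Oc1ccc2c(NCCCNCc3ccco3)ccnc2c1` differs from compound 3 by 2-methoxyphenoxy in place of phenethyl on an aromatic carbon. The three measured compounds carry quite different groups at this sort of position and yet read alike, so no step beyond the scatter is expected here. The step from compound 3 to compound 4 is estimated at no change at the digits printed from compound 3 to compound 4 (within the scatter). Compound 4 is expected at 9.47, within 9.15 to 9.8.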

Compound 4, acid dissociation constant: 9.28
Compound 4: middle estimate off by 0.19 log units, on the high side, within the range that was stated.
By their numbers in this assay, from the lowest: compounds 4, 1, 2 and 3 (each within the scatter of the next).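

Within the data shown here, replacing phenethyl with 2-methoxyphenoxy on this aromatic carbon gives, in this assay, a number 0.19 log units lower from compound 3 to compound 4 (within the scatter), the first direct single-point comparison at this position. A group with hydrogen-bond acceptors therefore replaces one with none, and the read-out stays within the scatter. No available measurement bears on the cause of this small step. As far as these compounds go, both groups carry no net charge, so it remains open whether an amine or a carboxylic acid on this aromatic carbon would move the read-out beyond the scatter.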